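The source may report more compounds than this note shows. Statements on the series, on what has been measured and on what is new or still open speak of the compounds shown alone.

The compounds here share one core, and they differ only in the group that sits on a carbon with a double bond to nitrogen. Compound 1 `CS(=O)(=O)c1ccc(Cc2nnc3n2N=C(c2cc(Cl)sc2Cl)CS3)cc1` carries 2,5-dichlorothiophen-3-yl at that position. In a functional assay on HT-29 cells (Homo sapiens) for cytotoxicity, read by MTT assay, with a stated time of 48 h, tested at 12.5 uM (on this read-out lower numbers stand for a weaker effect and higher numbers for a stronger effect at the one concentration tested), compound 1 is recorded as "not active" (no number reported), so no single number shows where it stands; it is simply noted as giving no measurable effect at the tested concentration. Compound 2 `CS(=O)(=O)c1ccc(Cc2nnc3n2N=C(c2ccc(Cl)cc2Cl)CS3)cc1` gives 28% in this assay, and compound 3 `CS(=O)(=O)c1ccc(Cc2nnc3n2N=C(c2cc4ccccc4c(=O)o2)CS3)cc1` gives 22.4% in this assay; these two readings lie within the usual scatter of each other, so neither can be placed ahead of the other. Compound 4 `CS(=O)(=O)c1ccc(Cc2nnc3n2N=C(c2ccc(O)c(C(N)=O)c2)CS3)cc1` has not been measured yet. The change from compound 1 to compound 4 is 3-carbamoyl-4-hydroxyphenyl in place of 2,5-dichlorothiophen-3-yl on a carbon with a double bond to nitrogen. Among the measured compounds shown here, no measured pair shows this same change, so the size of the step cannot be read from the data. Given that compound 1 came out as "not active" (no number reported) and that the two measured companions gave only modest readings, a small upward step at most is expected in this assay, and a reading that again falls in the inactive range would not be surprising. Compound 4 is therefore estimated at 15%, within a range from 0% to 35%.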

Compound 4, a percentage reported as activity, at one concentration (the size of the read-out at that concentration, not a potency): 24.8%
Compound 4: middle estimate off by 9.8 percentage points, on the low side, and the stated range covers the measured number.
By their numbers in this assay, from the lowest: compounds 3, 4 and 2 (each within the scatter of the next).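

In this assay this position accepts a group carrying hydrogen-bond donors in place of 2,5-dichlorothiophen-3-yl, which has none: compound 4 gives 24.8%, whereas compound 1 is recorded as "not active" (no number reported), and with no number on one side, the size of that step cannot be read. Exchanging 2,4-dichlorophenyl for 3-carbamoyl-4-hydroxyphenyl gives a number 3.2 percentage points lower from compound 2 to compound 4 (within the scatter), so on this read-out the ring with a hydroxyl and a carbamoyl group cannot be told apart from the ring with two chlorines. Compounds 2, 3 and 4 thus all lie within the scatter of one another despite carrying quite different groups, and compound 1 is the one that goes against this picture.

No measurement presented here explains why the dichlorothiophene stands apart from the other three groups. Also open, from the compounds shown here alone, is whether an amine, a carboxylic acid or a plain phenyl at this carbon would move the reading beyond the scatter, and whether the hydroxyl or the carbamoyl group of compound 4 matters on its own.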